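The source may report more compounds than this note shows. Statements on the series, on what has been measured and on what is new or still open speak of the compounds shown alone.

Measured so far:
- Compound 1 `C/C(=C\c1cc(-c2ccc(C)cc2)cs1)C(N)=O` gives > 50000 nM in a functional assay on A549 cells (Homo sapiens) for cytotoxicity, read by CCK-8 assay, with a stated time of 24 h (on this read-out lower numbers stand for stronger inhibition and higher numbers for weaker inhibition), a limit of the assay and not a number.
- Compound 2 `C/C(=C\c1cc(-c2ccc(C#N)cc2)cs1)C(N)=O` gives > 50000 nM in this assay, again a limit of the assay.
- Compound 3 `C/C(=C\c1cc(-c2ccc([N+](=O)[O-])cc2)cs1)C(N)=O` gives 3500 nM in this assay, the only actual number in the set.

Compound 3 therefore stands alone: the other two values sit at the limit of > 50000 nM in this assay, at which 2 of the 3 values shown sit. The next compound, compound 4 `COc1ccc(-c2csc(/C=C(\C)C(N)=O)c2)cc1`, differs from compound 3 by methoxy in place of nitro on an aromatic carbon.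

Among the measured compounds shown here, the steps that bear on this change are the two that put the nitro in: an at least 14-fold lower number from compound 1 to compound 3 (1.15 log units; beyond the scatter) and an at least 14-fold lower number from compound 2 to compound 3 (1.15 log units; beyond the scatter). The step that the two limits leave unreadable from compound 1 to compound 2 cannot be read. In both readable steps the nitro is what brings the number down; methyl and cyano both leave it at the limit. Methoxy is neither of these, but it is not the nitro, so the expectation is that compound 4 loses most or all of what compound 3 gained, giving a step of an 11-fold higher number from compound 3 to compound 4 (1.06 log units; beyond the scatter) in the direction of a higher number, beyond the scatter.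

Compound 4 is thus estimated at 40000 nM in this assay, with a range from 8000 nM to 200000 nM, and a real chance that only a limit is reported.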

Compound 4, half-maximal inhibitory concentration: > 50000 nM
Compound 4 ended at the assay's limit; the forecaster's own chance of this, stated with the estimate: 65%; middle value at least 1.2-fold (0.09 log units) away from the limit.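

In this assay compound 4 gives > 50000 nM as a limit of the assay and not a number. Methoxy in place of nitro on this aromatic carbon gives an at least 14-fold higher number from compound 3 to compound 4 (1.15 log units; beyond the scatter), so methoxy joins methyl and cyano at the limit, and nitro remains the only group here with a measured number: the limit of > 50000 nM in this assay, at which 3 of the 4 values shown sit. The steps joining compound 4 to compound 1 and to compound 2 cannot be read, both ends being limits, so methyl, cyano and methoxy cannot be ranked against one another.

Among the compounds shown here, the single number rests on compound 3 alone, which leaves open whether nitro is unique at this position or only the first group to give a reading. An amine or a carboxylic acid on the same carbon would test this.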